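A few compounds are considered here, and "the series" means these few. Any claim that something is new, unique, unknown or untested is made for them only; others in the source may bear on it.

Working notes on the series.

Compound 1 `CNC(=O)/C=C/CN1CC(Oc2ccc(Oc3c(-c4ccc(F)cc4)sc4cc(O)ccc34)cc2)C1` is known in a functional assay on Ishikawa cells (Homo sapiens) for antiproliferative activity, read by CCK-8 assay, with a stated time of 48 h (on this read-out higher numbers stand for weaker inhibition and lower numbers for stronger inhibition), only as a limit: compound 1 gives > 25000 nM, which is the limit of > 25000 nM in this assay, at which 2 of the 3 values shown sit. Compound 2 `C=CC(=O)NCCOc1ccc(Oc2c(-c3ccc(F)cc3)sc3cc(O)ccc23)cc1` likewise gives only the limit > 25000 nM in this assay. Among the measured compounds shown here, compound 3 `O=C(/C=C/CN1CC(Oc2ccc(Oc3c(-c4ccc(F)cc4)sc4cc(O)ccc34)cc2)C1)N1CCC1` gives 5450 nM in this assay, the one number in the set.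

Compound 4 `CN(C)C(=O)/C=C/CN1CC(Oc2ccc(Oc3c(-c4ccc(F)cc4)sc4cc(O)ccc34)cc2)C1` differs from compound 1 by methyl in place of hydrogen on an amide-type nitrogen. The step from compound 1 to compound 2 is unreadable: a step that the two limits leave unreadable from compound 1 to compound 2. The bearing step is the one on the same carbonyl carbon, an at least 4.5-fold lower number from compound 1 to compound 3 (0.66 log units; beyond the scatter), where methylamino became azetidin-1-yl. Dimethylamino is the smaller tertiary amide of the two, so for compound 4 a step in the same direction is expected, an at least 2.5-fold lower number from compound 1 to compound 4 (0.39 log units; beyond the scatter), though perhaps smaller. Compound 4 is therefore estimated at 10000 nM, within 4000 nM to 25000 nM.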

Compound 4, half-maximal inhibitory concentration: 11200 nM
Compound 4: the middle estimate sits 1.1-fold (0.05 log units) below what was measured; the range from low to high includes it.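

In this assay, methyl on the amide-type nitrogen alone gives an at least 2.2-fold lower number from compound 1 to compound 4 (0.34 log units; beyond the scatter), so a measurable value on this carbonyl carbon does not depend on azetidin-1-yl. The two tertiary amides still differ, with a 2.1-fold higher number from compound 3 to compound 4 (0.31 log units; beyond the scatter). The change of side chain gives an at least 2.2-fold lower number from compound 2 to compound 4 (0.34 log units; beyond the scatter); this step and the first are bounds only, because each starts from a limit: the limit of > 25000 nM in this assay, at which 2 of the 4 values shown sit.

On these data alone, the true size of those two bounded steps remains open. Also open, as far as these compounds go, is how diethylamino, pyrrolidin-1-yl or piperidin-1-yl on the same carbonyl carbon would compare with dimethylamino and azetidin-1-yl.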